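Enlarging the Oxime Group of Compound 3

The compounds below may be only part of what the source reports. "The series", "measured", "known", "first", "only" and "open" are said of these compounds alone.

Measured in a functional assay on MDA-MB-231 cells (Homo sapiens) for antiproliferative activity, with a stated time of 4 days (on this read-out higher numbers stand for weaker inhibition and lower numbers for stronger inhibition), so far
Compound 1 `CCCCc1ccc2[nH]c(-c3ccc(OC)cc3)c(C=O)c2c1` gives 6.7 nM
Compound 2 `COc1ccc(-c2[nH]c3ccc(C)cc3c2C=O)cc1` gives 86 nM
Compound 3 `CCCCc1ccc2[nH]c(-c3ccc(OC)cc3)c(/C=N/O)c2c1` gives 40 nM

Compound 3 holds the middle place among these three numbers, higher than that of compound 1 and lower than that of compound 2, with both gaps beyond the usual scatter. The next compound to be tested is compound 4 `CCCCc1ccc2[nH]c(-c3ccc(OC)cc3)c(/C=N/NC(=O)c3ccc(OC)cc3)c2c1`, in which ((4-methoxyphenyl)carbonyl)amino stands in place of hydroxy on a double-bonded nitrogen, a difference counted as ((4-methoxyphenyl)carbonyl)amino in place of hydroxy on a double-bonded nitrogen in full.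

Two measured steps offer some guidance. The closer one, a 6.0-fold higher number from compound 1 to compound 3 (0.78 log units; beyond the scatter), is modest and alters the same substituent that changes here. The other, a 13-fold higher number from compound 1 to compound 2 (1.11 log units; beyond the scatter), is large but lies on a saturated chain elsewhere in the molecule, so it bears on this change only loosely. Among the measured compounds shown here, no measured compound carries the entering group, which leaves the size of the effect poorly defined. A moderate rise in the number is therefore expected, rather than no change beyond the scatter. The estimated change is a 3.8-fold higher number from compound 3 to compound 4 (0.57 log units; beyond the scatter) in this assay, with wide uncertainty. Compound 4 is expected near 150 nM, within an estimated range of 30 nM to 800 nM in this assay when measured.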

Compound 4, half-maximal inhibitory concentration: 61 nM
Compound 4: the middle estimate sits 2.5-fold (0.39 log units) above what was measured, and the stated range covers the measured number.
By their numbers in this assay, from the lowest: compound 1; then compounds 3, 4 and 2 (each within the scatter of the next, the first and the last beyond it).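

In this assay, ((4-methoxyphenyl)carbonyl)amino in place of hydroxy on a double-bonded nitrogen gives a 1.5-fold higher number from compound 3 to compound 4 (0.18 log units; within the scatter), so the numbers of the two compounds stand within the scatter of each other even though the entering group brings 11 heavy atoms and one six-membered aromatic ring of carbon only, where hydroxy has no ring. The earlier compounds shown here offered only a 6.0-fold higher number from compound 1 to compound 3 (0.78 log units; beyond the scatter) at this substituent, and that step could not show that a group of this size is accommodated here without a shift beyond the scatter. The data shown give no measured basis for explaining why these two numbers lie so close.

From the compounds shown here alone, it remains open whether the same holds for other groups on the double-bonded nitrogen, such as an amine, a methoxy group or a chain carrying a carboxylic acid. Also open, going by these compounds, is whether a 13-fold higher number from compound 1 to compound 2 (1.11 log units; beyond the scatter), seen with the carbonyl group in place, would recur in a compound that carries ((4-methoxyphenyl)carbonyl)amino on the double-bonded nitrogen.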